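This account rests on a few compounds, and the source may have more. Where it says the series, first, only, none or still open, it means among the compounds named here.

Four compounds are compared here, and three of them have numbers in a functional assay on A549 cells (Homo sapiens) for cytotoxicity, read by MTT assay, with a stated time of 72 h; on this read-out lower numbers stand for stronger inhibition and higher numbers for weaker inhibition. Compound 1 (`CN(C)Cc1ccc2nc(NC(=O)N/N=C/c3cn(Cc4ccccc4Cl)c4ccccc34)sc2c1`) gives 1080 nM, compound 2 (`CC1CCN(Cc2ccc3nc(NC(=O)N/N=C/c4cn(Cc5ccc(Cl)cc5Cl)c5ccccc45)sc3c2)CC1`) gives 3640 nM and compound 3 (`CN(C)Cc1ccc2nc(NC(=O)N/N=C3\C(=O)Nc4ccc(F)cc43)sc2c1`) gives 2310 nM. The values of compound 2 and compound 3 lie within the usual scatter of each other. Compound 2 stands beyond the scatter above compound 1, which means weaker inhibition.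

Compound 4 (`CC1CCN(Cc2ccc3nc(NC(=O)N/N=C/c4c[nH]c5ccccc45)sc3c2)CC1`) is compound 2 with a single change: hydrogen in place of 2,4-dichlorobenzyl on an aromatic nitrogen. In words, this is hydrogen in place of 2,4-dichlorobenzyl on an aromatic nitrogen. Within the data shown here, no measured pair shows this change alone, so any forecast here is loose. Compound 1 and compound 2 both carry a benzyl group, while compound 3 carries none and still gives 2310 nM. This suggests that compound 4 should keep a measurable effect in this assay, though some weakening is a reasonable expectation when so large a group is lost. The expected change is a 1.6-fold higher number from compound 2 to compound 4 (0.22 log units; within the scatter), a small step toward a higher number, of about the size of the usual scatter. For compound 4 the estimate is 6000 nM, with an expected range from 2000 nM to 18000 nM.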

Compound 4, half-maximal inhibitory concentration: 3580 nM
Compound 4: middle estimate off by 1.7-fold (0.22 log units), on the high side; the measured number falls inside the stated range.
By their numbers in this assay, from the lowest: compound 1; then compounds 3, 4 and 2 (each within the scatter of the next).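

In this assay, hydrogen in place of 2,4-dichlorobenzyl on the aromatic nitrogen comes with a 1.0-fold lower number from compound 2 to compound 4 (0.01 log units; within the scatter), so compound 2 and compound 4 cannot be told apart on this read-out. Among these compounds, this pair isolates this position for the first time: with the rest of the molecule held fixed, a group of 9 heavy atoms, with its six-membered aromatic ring and two chlorine atoms, can be exchanged for a single hydrogen atom with no readable effect on the number. Nothing measured here explains why the number stays within the scatter across so large a change.

On these data alone, the two compounds cover only the bare nitrogen and one substituted benzyl group, so it remains open whether other groups on this nitrogen, such as a small methyl group or a longer chain ending in an amine or a carboxylic acid, would also leave the number within the scatter. As far as these compounds go, it also remains open whether the same exchange would read the same way on the core of compound 1, whose benzyl group and side chain differ from those of compound 2.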